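The source may report more compounds than this note shows. Statements on the series, on what has been measured and on what is new or still open speak of the compounds shown alone.

Of the compounds shown here, three built on one shared core have been tested in a functional assay on BCG823 cells (Homo sapiens) for inhibition, read by MTT assay, with a stated time of 72 h; a higher number here means a weaker inhibitor, a lower number a stronger inhibitor. Compound 1 `CN(C(=O)NC(=O)c1cccc(C(F)(F)F)c1)c1nc(C(F)(F)F)c(C(=O)N/N=C/c2cccc(C(F)(F)F)c2)s1` gives 4.6 ug/mL. Compound 2 `CN(C(=O)NC(=O)c1ccc(F)c(F)c1)c1nc(C(F)(F)F)c(C(=O)N/N=C/c2cccc(C(F)(F)F)c2)s1` gives 4.46 ug/mL in this assay, so that a 1.0-fold lower number from compound 1 to compound 2 (0.01 log units; within the scatter). Compound 3 `CN(C(=O)NC(=O)c1ccc(F)c(F)c1)c1nc(C(F)(F)F)c(C(=O)N/N=C/c2cc(C(F)(F)F)cc(C(F)(F)F)c2)s1` gives 3.51 ug/mL in this assay, and a 1.3-fold lower number from compound 2 to compound 3 (0.10 log units; within the scatter). Compound 3 thus sits within the usual scatter of both compound 1 and compound 2, and none of the three numbers can be told apart from the others with confidence.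

Compound 4 `CN(C(=O)NC(=O)c1cccc(C(F)(F)F)c1)c1nc(C(F)(F)F)c(C(=O)N/N=C/c2cc(C(F)(F)F)cc(C(F)(F)F)c2)s1` has not yet been measured. It differs from compound 3 in one place: 3-(trifluoromethyl)phenyl in place of 3,4-difluorophenyl on a carbonyl carbon. The same exchange, made in the opposite direction, separates compound 1 from compound 2, and there a 1.0-fold lower number from compound 1 to compound 2 (0.01 log units; within the scatter). Within the data shown here, that single step is the only direct guide, and it showed no movement beyond the scatter. The expectation for compound 4 is therefore no real shift in this assay, with a 1.0-fold higher number from compound 3 to compound 4 (0.01 log units; within the scatter). Compound 4 is estimated at 3.6 ug/mL, with a likely range from 1.8 ug/mL to 7.2 ug/mL.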

Compound 4, half-maximal inhibitory concentration: 5.23 ug/mL
Compound 4: the middle estimate sits 1.5-fold (0.16 log units) below what was measured; measured number inside the range.
By their numbers in this assay, from the lowest: compounds 3, 2, 1 and 4 (each within the scatter of the next).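

With a second pair now available, the exchange of 3,4-difluorophenyl for 3-(trifluoromethyl)phenyl on a carbonyl carbon can be read on two cores, and in this assay it gives a 1.5-fold higher number from compound 3 to compound 4 (0.17 log units; within the scatter). Read in the same direction, the two results for this exchange show no difference beyond the scatter: the same change on two cores in this assay, a 1.0-fold lower number (0.01 log units; within the scatter) from compound 1 to compound 2 and a 1.5-fold lower number (0.17 log units; within the scatter) from compound 4 to compound 3, 1.4-fold (0.16 log units) apart, within the scatter of two such steps The added trifluoromethyl on an aromatic carbon can now also be read twice, here with a 1.1-fold higher number from compound 1 to compound 4 (0.06 log units; within the scatter), and its two results also agree within the scatter: the same change on two cores in this assay, a 1.3-fold lower number (0.10 log units; within the scatter) from compound 2 to compound 3 and a 1.1-fold higher number (0.06 log units; within the scatter) from compound 1 to compound 4, 1.4-fold (0.16 log units) apart, within the scatter of two such steps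

From the compounds shown here alone, all four compounds carry a fluorine-bearing phenyl on that carbonyl carbon, so it remains open how this assay responds to an unsubstituted phenyl or to a phenyl carrying an amine or a carboxylic acid. With every step here within the scatter, the compounds shown do not establish that either place can move the number at all.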